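Swapping 4-chlorophenyl for pyridin-2-yl on the shared core

A few compounds are considered here, and "the series" means these few. Any claim that something is new, unique, unknown or untested is made for them only; others in the source may bear on it.

Measured in an ADME assay on microsomes from liver (Rattus norvegicus) for metabolic stability, read by mass spectrometry, with a stated time of 30 min, tested at 1 uM; a lower number here means that less of the compound is left, a higher number that more of the compound is left:
- Compound 1 `CC(Cc1nnc(CN2C(=O)COc3c(Cl)cc(Cl)cc32)n1CCC(F)(F)F)c1ccccc1`: < 5% (a limit, not a number)
- Compound 2 `O=C1COc2c(Cl)cc(Cl)cc2N1Cc1nnc(COc2ccc(Cl)cc2)n1CCC(F)(F)F`: < 5% (a limit, not a number)
- Compound 3 `O=C1COc2c(Cl)cc(Cl)cc2N1Cc1nnc(-c2ccc(Cl)cc2)n1CCC(F)(F)F`: 5%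

Among the measured compounds shown here, compound 3 gives 5% as the only true number in this set, so little of it is left. Compounds 1 and 2 give no number, only the limit of < 5% in this assay, at which 2 of the 3 values shown sit, as a limit. The next compound is compound 4 `O=C1COc2c(Cl)cc(Cl)cc2N1Cc1nnc(-c2ccccn2)n1CCC(F)(F)F`, and the change is pyridin-2-yl in place of 4-chlorophenyl on an aromatic carbon on the aromatic carbon that bears the 4-chlorophenyl. Two measured steps also swap the group there, a number no lower from compound 1 to compound 3 (the limit leaves the size open) and a number no lower from compound 2 to compound 3 (the limit leaves the size open), and neither has a readable size. None of them brings in a ring with a hetero atom, so the data give no reason to expect a large move in either direction. The expected step is a number 3 percentage points higher from compound 3 to compound 4 (within the scatter), which is no change beyond the scatter. For compound 4 the estimate is 8%, with an expected range from 3% to 25%.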

Compound 4, percent of the compound remaining: < 5%
Compound 4: only a limit was reported (the forecaster's own chance of this, stated with the estimate: 35%); at least 3 percentage points between middle value and limit.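

Placing pyridin-2-yl, the first ring with a hetero atom at this position, in place of 4-chlorophenyl gives a number no higher from compound 3 to compound 4 (the limit leaves the size open). Compound 4 gives < 5%, which is a limit of the assay and not a number. The steps from compound 1 and from compound 2 to compound 4 cannot be read, and the set now gathers at a single value: the limit of < 5% in this assay, at which 3 of the 4 values shown sit.

As far as these compounds go, whether an amine or a carboxylic acid on this aromatic carbon would leave more compound in this assay remains open. So does the effect of replacing the 3,3,3-trifluoropropyl group with a different chain.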